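Two hydrazone amides and a third awaiting its cytotoxicity number

The source may report more compounds than this note shows. Statements on the series, on what has been measured and on what is new or still open speak of the compounds shown alone.

Measured so far:
compound 1 `CC(/C=N/N(C)c1ccc([N+](=O)[O-])cc1)=N\NC(=O)c1cc([N+](=O)[O-])cc([N+](=O)[O-])c1` — 39000 nM
compound 2 `CC(/C=N/Nc1ccc([N+](=O)[O-])cc1)=N\NC(=O)c1ccccc1N` — 29800 nM

Both compounds were tested in an ADME assay on J774 cells (Mus musculus, strain BALB/c) for cytotoxicity, read by resazurin assay, with a stated time of 72 h; a lower number here means that less compound is tolerated, a higher number that more compound is tolerated. In this assay compound 1 gives 39000 nM, and compound 2 gives 29800 nM. The two numbers lie within the usual scatter of each other, so compound 2 stands on a par with compound 1: no difference between them can be read from these values. Within the data shown here, no pair of measured compounds differs in only one place, so no single step has been measured.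

Compound 3 `COc1cc(C(=O)N/N=C(C)/C=N/Nc2ccc([N+](=O)[O-])cc2)ccc1O` has not yet been measured. Set beside compound 2, it differs as follows: 4-hydroxy-3-methoxyphenyl in place of 2-aminophenyl on a carbonyl carbon. The two measured compounds give no guidance on what this exchange does, so the expectation for compound 3 rests on the two values alone. The step of a 1.2-fold higher number from compound 2 to compound 3 (0.07 log units; within the scatter) is expected to stay within the scatter, with no clear direction. On that basis compound 3 is estimated to give 35000 nM in this assay, within a range from 12000 nM to 100000 nM.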

Compound 3, half-maximal cytotoxic concentration: > 100000 nM
Compound 3 was reported as a limit; the forecaster's own chance of this, stated with the estimate: 15%; at least 2.8-fold (0.45 log units) between middle value and limit.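

On a carbonyl carbon whose other neighbour is an amide-type nitrogen, 4-hydroxy-3-methoxyphenyl in place of 2-aminophenyl gives an at least 3.3-fold higher number from compound 2 to compound 3 (0.52 log units; beyond the scatter) in this assay. Among these compounds, this is the first single change that can be read in these compounds, and it shows that what sits at this position can alter how much compound the J774 cells tolerate, which compound 1 and compound 2 could not show, since they differ in more than one place. The reading for compound 3 is a limit and not a number: the limit of > 100000 nM in this assay, at which 1 of the 3 values shown sits.

From the compounds shown here alone, the step therefore gives only a lower bound, and how far compound 3 lies past the limit stays open. Also open, going by these compounds, is which part of the entering group goes with the change, and whether a plain phenyl, a 4-hydroxyphenyl or a 3-methoxyphenyl on the same carbonyl carbon would give a number like that of compound 2 or a limit like that of compound 3.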